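A few compounds are considered here, and "the series" means these few. Any claim that something is new, unique, unknown or untested is made for them only; others in the source may bear on it.

Compound 3, whose structure is `O=C1c2ccccc2S(=O)(=O)N1CCCCCCN1CCN(c2cccc(C(F)(F)F)c2)CC1`, gives 58 nM in an ADME assay on HEK293 cells for displacement of a labelled ligand from 5-hydroxytryptamine receptor 7 (Homo sapiens), read by radioligand binding, with a stated time of 1 h (a lower number here means a stronger inhibitor, a higher number a weaker inhibitor), the lowest of the three numbers recorded. Compound 1, with structure `O=C1c2ccccc2S(=O)(=O)N1CCCCCCN1CCN(c2cccc(Cl)c2)CC1`, gives 233 nM in this assay, and compound 2, with structure `O=C1c2ccccc2S(=O)(=O)N1CCCCCCN1CCN(c2ccc(Cl)c(Cl)c2)CC1`, gives 258 nM; the step of a 1.1-fold higher number from compound 1 to compound 2 (0.04 log units; within the scatter) lies within the scatter. The two steps that reach compound 3 are a 4.0-fold lower number from compound 1 to compound 3 (0.60 log units; beyond the scatter) and a 4.4-fold lower number from compound 2 to compound 3 (0.65 log units; beyond the scatter), both modest and both showing that the group on the ring amine nitrogen moves the number.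

Compound 4, with structure `O=C1c2ccccc2S(=O)(=O)N1CCCCCCN1CCN(c2ncccn2)CC1`, carries a further change there: pyrimidin-2-yl in place of 3-(trifluoromethyl)phenyl on an amine nitrogen in a ring. Among the compounds with values here, no measured step swaps the phenyl ring itself for a different aromatic ring, so the measured steps only show that this position matters and that the number has so far stayed within a modest range. Since each measured change at this position shifted the number by a modest amount, compound 4 is expected to move back toward the numbers of compound 1 and compound 2, a step of about a 6.0-fold higher number from compound 3 to compound 4 (0.78 log units; beyond the scatter). The estimate for compound 4 in this assay is 350 nM, with a range from 90 nM to 1400 nM.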

Compound 4, inhibition constant: 35 nM
Beside the measured number, compound 4's estimate is 10-fold (1.00 log units) above it; measured number below the stated range.
By their numbers in this assay, from the lowest: compounds 4 and 3 (each within the scatter of the next); then compounds 1 and 2 (each within the scatter of the next).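

In this assay, within the data shown here, the earlier compounds all carried a substituted phenyl on the ring amine nitrogen, and compound 4 shows that this place also tolerates pyrimidin-2-yl, an aromatic ring with hetero atoms and fewer heavy atoms, with a 1.7-fold lower number from compound 3 to compound 4 (0.22 log units; within the scatter) leaving it level with compound 3. The steps of a 7.4-fold lower number from compound 2 to compound 4 (0.87 log units; beyond the scatter) and a 6.7-fold lower number from compound 1 to compound 4 (0.82 log units; beyond the scatter) show that this replacement also gives a clear gain over both chlorinated phenyl compounds, so neither a phenyl ring nor a halogen-bearing group is needed here for a number in this range. Nothing at hand explains why the change is tolerated. The compounds shown leave open whether a pyridin-2-yl group on the same nitrogen would give a similar number. They also leave open whether pyrimidin-2-yl would hold this number with a shorter chain on the shared core.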